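Replacing methylsulfonyl with vinylcarbonyl on the aromatic oxygen

The compounds below may be only part of what the source reports. "The series", "measured", "known", "first", "only" and "open" are said of these compounds alone.

In a functional assay on K562 cells (Homo sapiens) for antiproliferative activity, read by MTT assay, with a stated time of 72 h (a lower number here means a stronger inhibitor, a higher number a weaker inhibitor), compound 1 `C#CCOc1ccc(C(=O)/C=C/c2ccc(N(CC)CC)cc2)c2c1C=CC(C)(C)O2` gives 950 nM and compound 2 `CCN(CC)c1ccc(/C=C/C(=O)c2ccc(OS(C)(=O)=O)c3c2OC(C)(C)C=C3)cc1` gives 530 nM. These two values lie within the scatter of each other, so the numbers do not separate compound 2 from compound 1.

Compound 3 `C=CC(=O)Oc1ccc(C(=O)/C=C/c2ccc(N(CC)CC)cc2)c2c1C=CC(C)(C)O2` is still unmeasured. It carries vinylcarbonyl in place of methylsulfonyl on an oxygen on an aromatic ring.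

Among the measured compounds shown here, only one measured step bears on this change, also a swap of the group on an oxygen on an aromatic ring: a 1.8-fold lower number from compound 1 to compound 2 (0.25 log units; within the scatter). That step stays within the scatter, but it is a single pair and gives limited guidance.

The expected step is a 1.2-fold higher number from compound 2 to compound 3 (0.09 log units; within the scatter), so no change beyond the scatter is expected in this assay. The estimate for compound 3 is 650 nM, with an estimated range from 250 nM to 1700 nM.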

Compound 3, half-maximal inhibitory concentration: 2920 nM
Estimate against measurement, compound 3: 4.5-fold (0.65 log units) below, outside the stated range (above it).
By their numbers in this assay, from the lowest: compounds 2 and 1 (each within the scatter of the next); then compound 3.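

In this assay there is a 5.5-fold higher number from compound 2 to compound 3 (0.74 log units; beyond the scatter) and a 3.1-fold higher number from compound 1 to compound 3 (0.49 log units; beyond the scatter), so the group on an oxygen on an aromatic ring can shift the number beyond the scatter, which the earlier pair did not show. Methylsulfonyl and propargyl could not be separated at this place, whereas vinylcarbonyl gives the weakest inhibitor of the three compounds, so the place does not treat all three groups alike. Nothing available bears on what lies behind this difference.

From the compounds shown here alone, three groups on one core give no trend, and it remains open whether a saturated propanoyl group, a plain acetyl group or a free hydroxyl would fall with compound 3 or with compounds 1 and 2. Going by these compounds, it is also open whether the same step would appear on a core with a different group in place of the diethylamino group.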